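A few compounds are considered here, and "the series" means these few. Any claim that something is new, unique, unknown or untested is made for them only; others in the source may bear on it.

In a functional assay on KB cells (Homo sapiens) for cytotoxicity (on this read-out lower numbers stand for an effect already at smaller amounts and higher numbers for an effect only at larger amounts of compound), compound 1 `COC1=C(C)C(=O)/C(=C(O)/C=C/c2ccc(C)cc2)C(=O)C1(C)C` gives 1.9 ug/mL, compound 2 `COC1=C(C)C(=O)/C(=C(O)/C=C/c2ccccc2C)C(=O)C1(C)C` gives 1.6 ug/mL and compound 3 `COC1=C(C)C(=O)/C(=C(O)/C=C/c2cccc3ccccc23)C(=O)C1(C)C` gives 1.3 ug/mL. Compound 2 thus sits among these three numbers, within the scatter of both others. Compound 4 `COC1=C(C)C(=O)/C(=C(O)/C=C/c2nccs2)C(=O)C1(C)C` has not yet been measured. It carries 1,3-thiazol-2-yl in place of 2-methylphenyl on a double-bonded chain carbon bound to a double-bonded chain carbon. For the measured compounds named here, the only measured step at this place, a 1.2-fold lower number from compound 1 to compound 2 (0.07 log units; within the scatter), stays within the scatter, but it merely exchanges 4-methylphenyl for 2-methylphenyl. Going by the values given here, no measured compound carries a ring with hetero atoms here, so this guide is weak. The expected step is a 1.1-fold higher number from compound 2 to compound 4 (0.05 log units; within the scatter), which is no change beyond the scatter, and its direction is uncertain. For compound 4 the estimated value is 1.8 ug/mL, with an expected range from 0.8 ug/mL to 4 ug/mL.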

Compound 4, concentration for half-maximal effect: 3 ug/mL
Beside the measured number, compound 4's estimate is 1.7-fold (0.22 log units) below it, and the stated range covers the measured number.
By their numbers in this assay, from the lowest: compounds 3, 2, 1 and 4 (each within the scatter of the next, the first and the last beyond it).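

In this assay, the first ring with hetero atoms at this place gives a 1.9-fold higher number from compound 2 to compound 4 (0.27 log units; within the scatter) and also a 1.6-fold higher number from compound 1 to compound 4 (0.20 log units; within the scatter). Both steps stay within the scatter, so 1,3-thiazol-2-yl, a five-membered aromatic ring with 2 hetero atoms, can stand in for either methylphenyl group with no change that this read-out can separate. Nothing available explains these numbers. Still open, as far as these compounds go, is whether a pyridine ring, an amine or carboxylic acid on the ring, or a longer chain in its place would also leave the number unchanged.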